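Replacing the 2-(allyloxy)ethoxy group of compound 3

The source may hold more compounds than are shown below. What is called first, only, known or untested is meant among the compounds shown, and "the series" means these compounds.

- compound 1 `C=CCCCCOc1ccccc1-c1cnc(OCCCC=C)n1C`: 3000 nM
- compound 2 `C=CCCCCOc1ccccc1-c1cnc(OC)n1C`: 80000 nM
- compound 3 `C=CCCCCOc1ccccc1-c1cnc(OCCOCC=C)n1C`: 34000 nM

In a functional assay on A549 cells (Homo sapiens) for inhibition, read by colorimetric assay and MTT assay, with a stated time of 72 h (a lower number here means a stronger inhibitor, a higher number a weaker inhibitor), compound 3 stands second highest of the three numbers. Compound 4 `C=CCCCCOc1ccccc1-c1cnc(S(=O)(=O)c2ccccc2)n1C` differs from it as follows: phenylsulfonyl in place of 2-(allyloxy)ethoxy on an aromatic carbon. In words, phenylsulfonyl comes in place of 2-(allyloxy)ethoxy on an aromatic carbon. The measured steps all change the group at this same place. The step of an 11-fold higher number from compound 1 to compound 3 (1.05 log units; beyond the scatter) was large, the step of a 2.4-fold lower number from compound 2 to compound 3 (0.37 log units; beyond the scatter) was modest, and the step of a 27-fold higher number from compound 1 to compound 2 (1.43 log units; beyond the scatter) was large. For the measured compounds named here, none of the measured compounds carries phenylsulfonyl, so the direction stays uncertain. A modest move towards a lower number is expected in this assay, and the estimated step is a 1.7-fold lower number from compound 3 to compound 4 (0.23 log units; within the scatter). For compound 4 the estimated value is 20000 nM, with an expected range of 5000 nM to 80000 nM.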

Compound 4, half-maximal inhibitory concentration: 38000 nM
For compound 4 the middle estimate is 1.9-fold (0.28 log units) below the measured one; low and high end bracket the measured number.
By their numbers in this assay, from the lowest: compound 1; then compounds 3 and 4 (each within the scatter of the next); then compound 2.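

In this assay, phenylsulfonyl, which brings a six-membered aromatic ring of carbon only to this aromatic carbon, gives no change that can be told from scatter against 2-(allyloxy)ethoxy (a 1.1-fold higher number from compound 3 to compound 4 (0.05 log units; within the scatter)). Against methoxy the same group gives only a modest gain (a 2.1-fold lower number from compound 2 to compound 4 (0.32 log units; beyond the scatter)), while against (pent-4-en-1-yl)oxy it gives a large loss (a 13-fold higher number from compound 1 to compound 4 (1.10 log units; beyond the scatter)). Among these compounds, only the (pent-4-en-1-yl)oxy group of compound 1 stands apart by a large step from all the others.

As far as these compounds go, how an amine, a carboxylic acid or a longer chain at this place would compare stays open. Nothing available explains these differences.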